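Removing the 3-hydroxypropyl chain: what compound 4 may show

This account rests on a few compounds, and the source may have more. Where it says the series, first, only, none or still open, it means among the compounds named here.

Compound 3 `O=C(CCCN1CCC(C(O)(c2ccccc2)c2ccccc2)CC1)c1ccc(CCCO)cc1` stands highest of the three numbers in an in vitro assay on Sf9 cells for inhibition of cytochrome P450 2J2 (Homo sapiens) (a lower number here means a stronger inhibitor, a higher number a weaker inhibitor), at 1900 nM. Compound 1 `CCc1ccc(C(=O)CCCN2CCC(C(O)(c3ccccc3)c3ccccc3)CC2)cc1` gives 600 nM in this assay, and compound 2 `C=CCc1ccc(C(=O)CCCN2CCC(C(O)(c3ccccc3)c3ccccc3)CC2)cc1` gives 400 nM. Compound 4 `Cc1ccc(C(=O)CCCN2CCC(C(O)(c3ccccc3)c3ccccc3)CC2)cc1` differs from compound 3 by hydrogen in place of 2-hydroxyethyl on a saturated chain carbon bound to an aromatic carbon, which one bond further out reads 3-hydroxypropyl to methyl. For the measured compounds named here, two measured steps bear on this change: a 3.2-fold higher number from compound 1 to compound 3 (0.50 log units; beyond the scatter) and a 4.8-fold higher number from compound 2 to compound 3 (0.68 log units; beyond the scatter); both ended at compound 3 and both raised the number beyond the scatter. Compound 4 walks that chain back, so a modest step in the opposite direction is expected, namely a 3.2-fold lower number from compound 3 to compound 4 (0.50 log units; beyond the scatter). Compound 4 is therefore estimated at 600 nM in this assay, with a range from 250 nM to 1400 nM.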

Compound 4, half-maximal inhibitory concentration: 700 nM
Compound 4: the middle estimate sits 1.2-fold (0.07 log units) below what was measured; measured number inside the range.
By their numbers in this assay, from the lowest: compounds 2, 1 and 4 (each within the scatter of the next); then compound 3.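

Replacing 2-hydroxyethyl with hydrogen gives a 2.7-fold lower number from compound 3 to compound 4 (0.43 log units; beyond the scatter) in this assay, so at this saturated chain carbon only compound 3 stands apart. Hydrogen, methyl and vinyl cannot be told apart here, since a 1.2-fold higher number from compound 1 to compound 4 (0.07 log units; within the scatter) and a 1.8-fold higher number from compound 2 to compound 4 (0.24 log units; within the scatter) both stay within the scatter. Nothing available explains why the 2-hydroxyethyl group goes with the higher number. The compounds shown leave open whether the hydroxyl ending or the chain itself carries that rise. They also leave open where an amine, a carboxylic acid or a longer chain ending in hydroxyl would fall at this carbon.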